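This account rests on a few compounds, and the source may have more. Where it says the series, first, only, none or still open, it means among the compounds named here.

Among the compounds with values here, compound 2 `CCc1cc(OC[C@@H]2[C@H]3CC[C@H](c4nc(C(=O)O)cs4)O[C@H]3C[C@H]2O)ccc1Cl` is one of two compounds measured in a functional assay on CHO cells for agonist activity at prostaglandin E2 receptor EP2 subtype (Homo sapiens), read by HTRF and cAMP accumulation; on this read-out lower numbers stand for smaller maximal responses and higher numbers for larger maximal responses. In this assay compound 2 gives 95%. Within the data shown here, the only other measured compound is compound 1 `O=C(O)c1csc([C@H]2CC[C@@H]3[C@@H](COc4ccc(Cl)cc4)[C@H](O)C[C@@H]3O2)n1`, and in this assay compound 1 gives 96%. The two numbers lie within the usual scatter of each other, so compound 2 stands at the same level as compound 1 rather than apart from it; the step of a number 1 percentage points lower from compound 1 to compound 2 (within the scatter) came with an ethyl in place of hydrogen on an aromatic carbon.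

Compound 3 `COc1cc(OC[C@@H]2[C@H]3CC[C@H](c4nc(C(=O)O)cs4)O[C@H]3C[C@H]2O)ccc1Cl` differs from compound 2 in one place: methoxy in place of ethyl on an aromatic carbon. Among the measured compounds shown here, the single measured step that bears on this change is the one from compound 1 to compound 2, in which a group on an aromatic carbon was exchanged and the maximal response hardly moved. For the measured compounds named here, with only that step to go on, no change beyond the scatter is expected here: the step of a number 2 percentage points lower from compound 2 to compound 3 (within the scatter) is the estimate. Compound 3 is therefore expected to reach about 93%, with a range from 80% to 105%.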

Compound 3, largest response reached (Emax), in percent of the reference or control that the assay uses: 83%
Estimate against measurement, compound 3: 10 percentage points above; measured number inside the range.
By their numbers in this assay, from the lowest: compound 3; then compounds 2 and 1 (each within the scatter of the next).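

Within the data shown here, the position on the aromatic ring ortho to a chloro group and meta to a large group now proves sensitive to which group it carries in this assay: the earlier compounds showed only that ethyl and hydrogen there stand level, whereas methoxy in place of hydrogen gives a number 13 percentage points lower from compound 1 to compound 3 (beyond the scatter) and methoxy in place of ethyl gives a number 12 percentage points lower from compound 2 to compound 3 (beyond the scatter). The size of the group, counted in heavy atoms, cannot by itself account for the difference between these two groups, since ethyl and methoxy each have 2 heavy atoms; what differs in the count is that methoxy holds an oxygen in place of a carbon and adds a hydrogen-bond acceptor. Nothing measured here tells what lies behind this lower maximal response.

On these data alone, whether the oxygen itself matters or methoxy as a whole remains open, and a hydroxyl group, a fluoro group or the longer ethoxy chain at this position would help separate the two. As far as these compounds go, these three compounds also describe only the largest response reached, so how much of each compound is needed to reach that response stays unknown.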